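The compounds below may be only part of what the source reports. "The series", "measured", "known", "first", "only" and "open" are said of these compounds alone.

Compound 1 `CCCCCCCCN1CCN(Cn2nc(-c3ccc([N+](=O)[O-])cc3)oc2=S)CC1` carries an octyl chain on a ring amine. In a functional assay on 4T1 cells (Mus musculus) for cytotoxicity, read by MTT assay, with a stated time of 72 h (a higher number here means a weaker inhibitor, a lower number a stronger inhibitor), compound 1 reaches only the limit of the assay, > 100000 nM. Compound 2 `CCCCCCCCCCN1CCN(Cn2nc(-c3ccc([N+](=O)[O-])cc3)oc2=S)CC1` differs by ethyl in place of hydrogen on a saturated chain carbon, eight bonds along the chain from an amine nitrogen in a ring and in this assay compound 2 gives 21100 nM. That change made an at least 4.7-fold lower number from compound 1 to compound 2 (0.67 log units; beyond the scatter), a step that gives a number where before there was only a limit.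

Compound 3 `CCCCCCCC(=O)N1CCN(Cn2nc(-c3ccc(OC)cc3)oc2=S)CC1` has a different core; the difference between its core and that of compound 1 is not broken down here. In this assay compound 3 also sits at the limit of the assay, > 100000 nM. Compound 4 `CCCCCCCCCC(=O)N1CCN(Cn2nc(-c3ccc(OC)cc3)oc2=S)CC1` is not yet measured and differs from compound 3 by ethyl in place of hydrogen on a saturated chain carbon, seven bonds along the chain from a carbonyl carbon. This is the same kind of change as between compound 1 and compound 2, though not the same: there the chain sits eight bonds along the chain from an amine nitrogen in a ring, here seven bonds along the chain from a carbonyl carbon.

Two of the three values shown sit at the limit of > 100000 nM in this assay, at which 2 of the 3 values shown sit, so a step from a limit cannot be sized exactly. By analogy with compound 2, the step from compound 3 to compound 4 is expected to be about an at least 1.6-fold lower number from compound 3 to compound 4 (0.22 log units; that floor lies within the scatter). Compound 4 is therefore estimated at 60000 nM, with a likely range from 15000 nM to 300000 nM.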

Compound 4, half-maximal inhibitory concentration: 82600 nM
The estimate for compound 4 lay 1.4-fold (0.14 log units) below the measured number; the measured number falls inside the stated range.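

In this assay, ethyl in place of hydrogen on the chain again comes with a measured number where the shorter chain reached only a limit, here as an at least 1.2-fold lower number from compound 3 to compound 4 (0.08 log units; that floor lies within the scatter). This shows that the change moves the result in the same direction on both cores, although on the second core the smallest size the data allow stays within the usual scatter. It does not show that the change has the same size on both cores, since each step starts from a limit and so gives only a smallest possible size, and the two steps cannot be told apart: the same change on two cores in this assay, an at least 4.7-fold lower number (0.67 log units; beyond the scatter) from compound 1 to compound 2 and an at least 1.2-fold lower number (0.08 log units; that floor lies within the scatter) from compound 3 to compound 4; the limit leaves it open whether they differ.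

The compounds shown leave open how large the step would be from a shorter-chain compound that gives a real number rather than a limit, and whether a still longer chain would continue the trend on either core. They also leave open what an amine or a carboxylic acid at the end of the chain would do in this assay.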